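The source may hold more compounds than are shown below. What is called first, only, known or untested is meant among the compounds shown, and "the series" means these compounds.

Three measured compounds have been run in an ADME assay on BEAS-2B cells (Homo sapiens) for inhibition, read by MTT assay, with a stated time of 24 h; on this read-out higher numbers stand for weaker inhibition and lower numbers for stronger inhibition. Compound 1 `Cc1ccc(NC(=O)COc2nc3ccccc3nc2C)cc1` gives only a limit there, > 100000 nM. Compound 2 `Cc1nc2ccccc2nc1OCC(=O)Nc1ccc(Cl)cc1` likewise gives a limit, > 100000 nM. The two differ by a single change, (chloro in place of methyl on an aromatic carbon), and the step that the two limits leave unreadable from compound 1 to compound 2 cannot be sized because the limit of > 100000 nM in this assay, at which 3 of the 3 values shown sit, covers both of its ends. Compound 3 `Cc1ccc(C(=O)Nc2ccc(Cn3c(=O)c(C)nc4ccccc43)cc2)cc1` rests on another core, and how that core differs from the core of compound 1 is not broken down here. In this assay compound 3 also gives a limit, > 100000 nM. Compound 4 `Cc1nc2ccccc2n(Cc2ccc(NC(=O)c3ccc(Cl)cc3)cc2)c1=O` has not yet been measured. It differs from compound 3 by chloro in place of methyl on an aromatic carbon, the same change at the same place as between compound 1 and compound 2, so this change appears twice among the compounds shown. With every measured value sitting at the same limit, the earlier step offers no measure of size. The step expected here is a step that the limit leaves unreadable from compound 3 to compound 4, resting on compound 3 at > 100000 nM. Compound 4 is estimated at 150000 nM, between 50000 nM and 1000000 nM, and most likely will again be reported only as a limit.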

Compound 4, half-maximal inhibitory concentration: > 100000 nM
Compound 4: a limit, no number; the forecaster's own chance of this, stated with the estimate: 85%; the middle value is on the limit's open side.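

In this assay compound 4 gives > 100000 nM, which is a limit and not a number. No size can be read for the change from compound 3 to compound 4, because both rest on the same limit: the limit of > 100000 nM in this assay, at which 4 of the 4 values shown sit.

The compounds shown leave open whether chloro in place of methyl alters inhibition at all in this assay.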